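A few compounds are considered here, and "the series" means these few. Any claim that something is new, unique, unknown or untested is made for them only; others in the source may bear on it.

Going by the values given here, in a functional assay on SiHa cells (Homo sapiens) for inhibition, read by sulforhodamine B assay (on this read-out lower numbers stand for stronger inhibition of growth and higher numbers for weaker inhibition of growth), compound 1 (`c1ccc(-c2ccc(-c3ccc(-c4nc5ccccc5[nH]4)cc3)cc2)cc1`) gives 100000 nM and holds the higher of the two numbers measured so far. Among the compounds with values here, the only other measured compound, compound 2 (`COc1cc(-c2ccc(-c3ccc(-c4nc5cc(C)ccc5[nH]4)cc3)cc2)cc(OC)c1OC`), gives 170 nM and so sits far lower, a gap well beyond the usual scatter. Within the data shown here, these two compounds differ in more than one place, so their gap cannot be assigned to any single change, and no measured one-place step is available as a guide.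

Compound 3 (`Clc1cccc(-c2ccc(-c3ccc(-c4nc5ccccc5[nH]4)cc3)cc2)c1`) departs from compound 1 in just one place. Phenyl becomes 3-chlorophenyl, with chloro in place of hydrogen on an aromatic carbon, meta to a large group (chloro in place of hydrogen on an aromatic carbon). Compound 2 reaches 170 nM with changes in several places, whereas compound 3 carries one, so only a small part of that gap is expected here. The estimate is a moderate move toward stronger inhibition of growth, a 5.0-fold lower number from compound 1 to compound 3 (0.70 log units; beyond the scatter) as the expected step, modestly beyond the scatter. For compound 3 the expected value is 20000 nM with an estimated range from 3000 nM to 100000 nM for the coming measurement.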

Compound 3, concentration for 50% growth inhibition: 100000 nM
Estimate against measurement, compound 3: 5.0-fold (0.70 log units) below; low and high end bracket the measured number.
By their numbers in this assay, from the lowest: compound 2; then compounds 1 and 3 (each within the scatter of the next).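

Phenyl to 3-chlorophenyl is the first one-place change that can be read in this series, and in this assay it gives no change at the digits printed from compound 1 to compound 3 (within the scatter). At this aromatic carbon, meta to a large group, chloro in place of hydrogen therefore shows no measurable gain in inhibition of growth on the core of compound 1. No measurement here bears on why this step is flat.

On these data alone, one chloro at one position is a narrow test, so it remains open whether a different group on the same carbon, such as an amine or a carboxylic acid, would shift the number, or whether chloro would do so elsewhere on the ring. Going by these compounds alone, it also remains open which of the several differences between compound 1 and compound 2 carry their large gap, as no one-place step connects those two compounds.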